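A small methylation step toward a prenylated benzoic acid

A few compounds are considered here, and "the series" means these few. Any claim that something is new, unique, unknown or untested is made for them only; others in the source may bear on it.

The set comprises three measured compounds and one awaiting measurement. Compound 1 `COc1cc(/C=C/C(=O)O)ccc1OCC=C(C)C` and compound 2 `CC(C)=CCC/C(C)=C/CC/C(C)=C/COc1ccc(/C=C/C(=O)O)cc1O` carry an acrylic acid on their aromatic ring, while compound 3 `CC(C)=CCOc1ccc(C(=O)O)cc1O` carries the acid directly on the ring. In an assay on isolated protein for inhibition of geranylgeranyl pyrophosphate synthase (Homo sapiens), tested at 100 uM (on this read-out lower numbers stand for less inhibition and higher numbers for more inhibition at the one concentration tested (going by the name of the read-out)), compound 1 gives 9.3%, compound 2 gives 16.2% and compound 3 gives 0%. Compound 3 thus stands at the low end of the three numbers; its value and that of compound 1 lie within the usual scatter of each other, whereas compound 2 lies beyond that scatter above it.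

Compound 4 `COc1cc(C(=O)O)ccc1OCC=C(C)C` is the next compound to be examined. It differs from compound 3 in one place: methyl in place of hydrogen on an oxygen on an aromatic ring, which, read one bond further out, is a change of hydroxy to methoxy. Within the data shown here, no step between two measured compounds isolates this change, so its effect is not known from the data in hand. Given that compound 3 gives 0% and that the change is a single methyl, compound 4 is expected to show a step of a number 5 percentage points higher from compound 3 to compound 4 (within the scatter) in this assay, which would leave it within the scatter of compound 3. Compound 4 is therefore estimated at 5%, with a range from 0% to 20%.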

Compound 4, a percentage reported as inhibition, at one concentration (the size of the read-out at that concentration, not a potency): 2.4%
Beside the measured number, compound 4's estimate is 2.6 percentage points above it, and the stated range covers the measured number.
By their numbers in this assay, from the lowest: compounds 3, 4, 1 and 2 (each within the scatter of the next, the first and the last beyond it).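

In this assay, methyl in place of hydrogen on an oxygen on an aromatic ring, read one bond further out as hydroxy to methoxy, gives a number 2.4 percentage points higher from compound 3 to compound 4 (within the scatter) and so marks this change as one that cannot be told from the usual scatter here. Among these compounds, compound 4 also provides the first direct comparison of the two acid-bearing groups, since carboxy in place of 2-carboxyethenyl on an aromatic carbon gives a number 6.9 percentage points lower from compound 1 to compound 4 (within the scatter) and thus likewise stays within the scatter in this assay. Nothing in hand speaks to what lies behind either of these steps.

The compounds leave open whether the change of hydroxy to methoxy would read the same on the core of compound 2, which carries a longer chain, or whether an ethoxy group on that same oxygen would move the number beyond the scatter. As far as these compounds go, it also remains open how the carboxy-bearing core of compound 4 would read with a geranyl chain on its other oxygen, or with a primary amide in place of the carboxy group.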